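Hydroxymethyl Added to an Aryl Thiazole Cytotoxic

The source may hold more compounds than are shown below. What is called first, only, known or untested is meant among the compounds shown, and "the series" means these compounds.

Compound 1 `OC1CNCc2nc(-c3ccc(N4CCCC4)cc3)sc21`: 730 nM
Compound 2 `CN(C)c1ccc(-c2nc3c(s2)C(O)CCC3)c(CO)c1`: 60 nM

In a functional assay on HCT-116 cells (Homo sapiens) for cytotoxicity, read by sulforhodamine B assay, with a stated time of 2 days (on this read-out higher numbers stand for weaker inhibition and lower numbers for stronger inhibition), compound 1 gives 730 nM, the highest of the two numbers; compound 2 sits far lower at 60 nM, a gap beyond the scatter. Compound 3 `OCc1cc(N2CCCC2)ccc1-c1nc2c(s1)C(O)CNC2` is not yet measured. It differs from compound 1 by hydroxymethyl in place of hydrogen on an aromatic carbon. Compound 2 also carries a hydroxymethyl group, but it differs from compound 1 in other places too, so no single step can be read from it. A modest improvement is expected for compound 3, a 2.9-fold lower number from compound 1 to compound 3 (0.47 log units; beyond the scatter). The estimate for compound 3 is 250 nM, within 60 nM to 1000 nM.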

Compound 3, half-maximal inhibitory concentration: 70 nM
Estimate against measurement, compound 3: 3.6-fold (0.55 log units) above; the measured number falls inside the stated range.
By their numbers in this assay, from the lowest: compounds 2 and 3 (each within the scatter of the next); then compound 1.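

In this assay hydroxymethyl in place of hydrogen on an aromatic carbon, ortho to a large group and meta to a pyrrolidin-1-yl group, gives a 10-fold lower number from compound 1 to compound 3 (1.02 log units; beyond the scatter) and counts as a large step. Among the compounds shown here, this is the first single change that can be read at this position, and it shows that the position responds strongly to this small group. No measurement shown here accounts for the gain.

From the compounds shown here alone, whether a methyl, methoxy or aminomethyl group on the same aromatic carbon would give a step of like size stays open. So does whether a longer chain ending in hydroxyl would keep it.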